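Methoxy for ethyl on the 4-ethylphenyl group

This account rests on a few compounds, and the source may have more. Where it says the series, first, only, none or still open, it means among the compounds named here.

Compound 1 `CC(C)n1ncc2c(C(=O)NCc3cn(-c4ccccc4)nn3)cccc21` and compound 2 `CCc1ccc(-n2cc(CNC(=O)c3cccc4c3cnn4C(C)C)nn2)cc1` share one core and differ only in the ethyl in place of hydrogen on an aromatic carbon. In a functional assay on HepG2 cells (Homo sapiens) for inhibition, read by MTT assay, with a stated time of 72 h (a higher number here means a weaker inhibitor, a lower number a stronger inhibitor), compound 1 reaches only the limit of the assay, > 40000 nM. Compound 2 likewise stops at the limit of this assay, > 40000 nM. The step that the two limits leave unreadable from compound 1 to compound 2 is therefore not sized; both entries sit at the limit of > 40000 nM in this assay, at which 2 of the 2 values shown sit. Compound 3 `COc1ccc(-n2cc(CNC(=O)c3cccc4c3cnn4C(C)C)nn2)cc1` differs from compound 2 by methoxy in place of ethyl on an aromatic carbon. Among the compounds with values here, only the step from compound 1 to compound 2 bears on this position, and it cannot be read, so neither a size nor a direction can be drawn from it. Compound 3 is expected to remain at or near the limit of this assay, estimated at 60000 nM with a range from 20000 nM to 200000 nM. The step so expected is a step that the limit leaves unreadable from compound 2 to compound 3, which is no step beyond the scatter that the numbers could show.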

Compound 3, half-maximal inhibitory concentration: > 40000 nM
Compound 3: no number, only a limit; the forecaster's own chance of this, stated with the estimate: 85%; the middle value lies beyond the limit too.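

In this assay no step can be read among compound 1, compound 2 and compound 3, and all three stop at the same limit: the limit of > 40000 nM in this assay, at which 3 of the 3 values shown sit. Going by these compounds, whether hydrogen, ethyl or methoxy at this position makes any difference to inhibition, and in which direction, remains open.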